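Furan-3-yl to thiophen-2-yl: compound 3 to compound 4

This account rests on a few compounds, and the source may have more. Where it says the series, first, only, none or still open, it means among the compounds named here.

Values in a functional assay on CCRF-CEM cells (Homo sapiens), read by MTT assay, with a stated time of 72 h; on this read-out higher numbers stand for weaker inhibition and lower numbers for stronger inhibition:
- compound 1 `CSc1ncnc2c1c(-c1cccs1)cn2[C@@H]1O[C@H](CO)[C@@H](O)[C@H]1O`: > 20000 nM (a limit)
- compound 2 `CNc1ncnc2c1c(-c1ccco1)cn2[C@@H]1O[C@H](CO)[C@@H](O)[C@H]1O`: 180 nM
- compound 3 `CNc1ncnc2c1c(-c1ccoc1)cn2[C@@H]1O[C@H](CO)[C@@H](O)[C@H]1O`: > 20000 nM (a limit)

Compound 3 stands at the limit of > 20000 nM in this assay, at which 2 of the 3 values shown sit, and so has no number. Compound 4 `CNc1ncnc2c1c(-c1cccs1)cn2[C@@H]1O[C@H](CO)[C@@H](O)[C@H]1O` has thiophen-2-yl in place of furan-3-yl on an aromatic carbon as its change. Among the measured compounds shown here, the one measured step bearing on this is an at least 110-fold higher number from compound 2 to compound 3 (2.04 log units; beyond the scatter) which is large and beyond the scatter. Compound 4 regains a 2-yl ring like compound 2 at 180 nM and a large step towards lower numbers is therefore expected in this assay here. Compound 1 goes against this: it also carries thiophen-2-yl but reports only a limit. The expected step is an at least 50-fold lower number from compound 3 to compound 4 (1.69 log units; beyond the scatter) in that direction. The estimated value for compound 4 is 400 nM with an expected range from 60 nM to 5000 nM overall.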

Compound 4, half-maximal inhibitory concentration: > 20000 nM
Compound 4 gave a limit, no number; the forecaster's own chance of this, stated with the estimate: 15%; middle value at least 50-fold (1.69 log units) away from the limit.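

With methylamino held, thiophen-2-yl in place of furan-2-yl in this assay gives an at least 110-fold higher number from compound 2 to compound 4 (2.04 log units; beyond the scatter), so a 2-yl attachment alone does not keep a measurable value at this aromatic carbon, and among these methylamino compounds only the furan-2-yl of compound 2 does. The steps from compound 3 and from compound 1 to compound 4 cannot be read, as both ends are limits: the limit of > 20000 nM in this assay, at which 3 of the 4 values shown sit.

Thiophen-2-yl and furan-3-yl therefore stay unranked, as do methylamino and methylsulfanyl. Also open, on these data alone, is whether a phenyl or pyrrol-2-yl ring on this carbon would give a number.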